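The source may report more compounds than this note shows. Statements on the series, on what has been measured and on what is new or still open speak of the compounds shown alone.

Three compounds built on a shared core that carries two hydroxyphenyl groups and one trifluoromethylphenyl group have been tested in a functional assay on HCT-15 cells (Homo sapiens) for inhibition; a higher number here means a weaker inhibitor, a lower number a stronger inhibitor. Compound 1 `Oc1cccc(-c2cc(-c3cccc(C(F)(F)F)c3)cc(-c3cccc(O)c3)n2)c1` gives 13600 nM in this assay. Compound 3 `Oc1ccc(-c2cc(-c3cccc(C(F)(F)F)c3)cc(-c3cccc(O)c3)n2)cc1` gives 9540 nM in this assay. For compound 2 `Oc1cccc(-c2cc(-c3ccc(C(F)(F)F)cc3)cc(-c3cccc(O)c3)n2)c1` the result in this assay is a limit of the assay rather than a number, > 50000 nM; it sits at the limit of > 50000 nM in this assay, at which 1 of the 3 values shown sits.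

The change from compound 1 to compound 2 is 4-(trifluoromethyl)phenyl in place of 3-(trifluoromethyl)phenyl on an aromatic carbon, and it brought an at least 3.6-fold higher number from compound 1 to compound 2 (0.56 log units; beyond the scatter). The change from compound 1 to compound 3 is 4-hydroxyphenyl in place of 3-hydroxyphenyl on an aromatic carbon, and it brought a 1.4-fold lower number from compound 1 to compound 3 (0.15 log units; within the scatter), so the numbers of compound 1 and compound 3 cannot be told apart here.

Compound 4 `Oc1ccc(-c2cc(-c3ccc(C(F)(F)F)cc3)cc(-c3cccc(O)c3)n2)cc1` has not yet been measured. It differs from compound 3 by 4-(trifluoromethyl)phenyl in place of 3-(trifluoromethyl)phenyl on an aromatic carbon. Going by the values given here, this is the same kind of change as the one from compound 1 to compound 2, but not the same change: in compound 1 the place is meta to two 3-hydroxyphenyl groups, whereas in compound 3 it is meta to a 3-hydroxyphenyl group and meta to a 4-hydroxyphenyl group. The two cores differ by 4-hydroxyphenyl in place of 3-hydroxyphenyl on an aromatic carbon.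

The earlier move of this kind gave an at least 3.6-fold higher number from compound 1 to compound 2 (0.56 log units; beyond the scatter). For compound 4 a step of similar size is expected, namely a 4.2-fold higher number from compound 3 to compound 4 (0.62 log units; beyond the scatter). Compound 4 is therefore estimated at 40000 nM in this assay, most likely between 15000 nM and 120000 nM, and a result reported only as a limit would not be surprising.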

Compound 4, half-maximal inhibitory concentration: 6440 nM
Estimate against measurement, compound 4: 6.2-fold (0.79 log units) above; the whole stated range lies above it.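

Carried to the core of compound 3, the move from 3-(trifluoromethyl)phenyl to 4-(trifluoromethyl)phenyl gave a 1.5-fold lower number from compound 3 to compound 4 (0.17 log units; within the scatter) in this assay, so it did not repeat the clear loss seen on the core of compound 1, and the two steps differ: the same change on two cores in this assay, an at least 3.6-fold higher number (0.56 log units; beyond the scatter) from compound 1 to compound 2 and a 1.5-fold lower number (0.17 log units; within the scatter) from compound 3 to compound 4, at least 5.4-fold (0.73 log units) apart, beyond the scatter of two such steps.

The other change tells the same story from the opposite side, since 4-hydroxyphenyl in place of 3-hydroxyphenyl gave an at least 7.7-fold lower number from compound 2 to compound 4 (0.89 log units; beyond the scatter) on the core carrying 4-(trifluoromethyl)phenyl, yet made no readable difference on the core carrying 3-(trifluoromethyl)phenyl: the same change on two cores in this assay, a 1.4-fold lower number (0.15 log units; within the scatter) from compound 1 to compound 3 and an at least 7.7-fold lower number (0.89 log units; beyond the scatter) from compound 2 to compound 4, at least 5.4-fold (0.73 log units) apart, beyond the scatter of two such steps.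

So within these four compounds, the result of one change depends on what stands elsewhere on the core, but this does not show why, and compound 2 at > 50000 nM is a limit of the assay and not a number, which leaves the true size of the gap between the steps unknown.

The compounds shown leave open whether this dependence extends beyond the hydroxyphenyl and trifluoromethylphenyl groups, for example to a phenyl ring carrying a nitrile or a chlorine in place of trifluoromethyl, or an amine in place of hydroxyl. They also leave open whether a core with both hydroxyl groups in other arrangements would follow compound 3 and compound 4 or compound 1 and compound 2.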